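Cytotoxicity of nitrofuran amides: methoxy to trifluoromethyl

A few compounds are considered here, and "the series" means these few. Any claim that something is new, unique, unknown or untested is made for them only; others in the source may bear on it.

Compound 1 `CC(C)(NC(=O)c1ccc([N+](=O)[O-])o1)c1ccccc1` in an ADME assay on Vero cells (Chlorocebus sabaeus) for cytotoxicity, read by MTT assay, with a stated time of 48 h (a lower number here means that less compound is tolerated, a higher number that more compound is tolerated), gives only a limit, > 180000 nM.
Compound 2 `CC(C)(NC(=O)c1ccc([N+](=O)[O-])o1)c1ccc(COc2ccc(Cl)cc2)cc1` in this assay gives 120000 nM.
Compound 3 `COc1ccc(OCc2ccc(C(C)(C)NC(=O)c3ccc([N+](=O)[O-])o3)cc2)cc1` in this assay gives only a limit, > 120000 nM.

Two of the three values shown are limits rather than numbers, as the limit of > 120000 nM in this assay, at which 1 of the 3 values shown sits, and the limit of > 180000 nM in this assay, at which 1 of the 3 values shown sits, record. Compound 3 therefore stands at a limit in this assay, and no ordering among the three compounds can be read beyond the scatter. The step of an at least 1.5-fold lower number from compound 1 to compound 2 (0.17 log units; that floor lies within the scatter) has a floor that lies within the scatter; the step that the two limits leave unreadable from compound 1 to compound 3 is unreadable between two limits; and the step of a number no lower from compound 2 to compound 3 (the limit leaves the size open) is open in size.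

Compound 4 `CC(C)(NC(=O)c1ccc([N+](=O)[O-])o1)c1ccc(COc2ccc(C(F)(F)F)cc2)cc1` differs from compound 3 by trifluoromethyl in place of methoxy on an aromatic carbon. The step that bears most directly on it is a number no lower from compound 2 to compound 3 (the limit leaves the size open), which exchanged one group at the same place and gave no readable change; the other two steps likewise show nothing beyond the scatter. In this assay, then, compound 4 is expected to show no step beyond the scatter, a number no higher from compound 3 to compound 4 (the limit leaves the size open). Compound 4 is accordingly estimated at 120000 nM, with a range from 50000 nM to 250000 nM, and a fair chance that the assay again reports only a limit.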

Compound 4, half-maximal cytotoxic concentration: 7000 nM
Compound 4: middle estimate off by 17-fold (1.23 log units), on the high side; measured number outside the range, below it.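

In this assay, the group at this place turns out to matter: trifluoromethyl in place of methoxy gives an at least 17-fold lower number from compound 3 to compound 4 (1.23 log units; beyond the scatter), and trifluoromethyl in place of chloro gives a 17-fold lower number from compound 2 to compound 4 (1.23 log units; beyond the scatter). Among the compounds shown here, the earlier exchange at this same place, methoxy for chloro, left no readable change, so these are the first steps here that lie beyond the scatter, and both run towards less compound being tolerated; the step from chloro is the firmer of the two, as it joins two measured numbers. Compound 3 stands at a limit, so the step from methoxy is only a floor and its full size remains open: the limit of > 120000 nM in this assay, at which 1 of the 4 values shown sits.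

The compounds shown do not tell whether this large step belongs to trifluoromethyl alone or would also appear with other groups at this place, such as a nitrile, an amine or a carboxylic acid. Nor do they tie the step to any particular property of the group, or show whether it would hold on a core other than the one shared by these compounds.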